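The source may report more compounds than this note shows. Statements on the series, on what has been measured and on what is new or still open speak of the compounds shown alone.

Measured compounds:
- compound 1, `COc1cc(OC)c(C(=O)/C=C/c2ccc(Cl)cc2)c(OC)c1`, 5700 nM
- compound 2, `COc1cc(OC)c(C(=O)/C=C/c2ccccc2SC)c(OC)c1`, 8800 nM
- compound 3, `COc1cc(O)c(C(=O)/C=C/c2ccccc2SC)c(OC)c1`, 9600 nM

All three were tested in a functional assay on Caco-2 cells (Homo sapiens) for cytotoxicity, with a stated time of 48 h; a lower number here means a stronger inhibitor, a higher number a weaker inhibitor. Compound 2 stands second highest of the three numbers; its nearest neighbour is compound 3, and a 1.1-fold higher number from compound 2 to compound 3 (0.04 log units; within the scatter), while the gap back to compound 1 is also small, since a 1.5-fold higher number from compound 1 to compound 2 (0.19 log units; within the scatter). All three compounds therefore sit within the scatter of one another, and no order among them can be claimed.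

Compound 4, `COc1cc(OC)c(C(=O)/C=C/c2ccc(F)cc2)c(OC)c1`, has not yet been measured. It differs from compound 2 in one place: 4-fluorophenyl in place of 2-(methylsulfanyl)phenyl on a double-bonded chain carbon bound to a double-bonded chain carbon. Within the data shown here, the one measured step that bears on this change is the one between compound 1 and compound 2, where the same position carries 4-chlorophenyl rather than 2-(methylsulfanyl)phenyl, and that step stayed within the scatter. A halogen on the ring, as in compound 1, and the methylsulfanyl group of compound 2 gave numbers close together, so no step beyond the scatter is expected in this assay for compound 4 either; if anything, the number is expected to lean slightly toward that of compound 1, giving an expected 1.4-fold lower number from compound 2 to compound 4 (0.13 log units; within the scatter). Compound 4 is estimated at 6500 nM, with a range from 3000 nM to 14000 nM.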

Compound 4, half-maximal inhibitory concentration: 5500 nM
Compound 4: the middle estimate sits 1.2-fold (0.07 log units) above what was measured; the range from low to high includes it.
By their numbers in this assay, from the lowest: compounds 4, 1, 2 and 3 (each within the scatter of the next).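

Compound 4 puts a second halogen-bearing ring at this position: with 4-fluorophenyl in place of 2-(methylsulfanyl)phenyl, this assay shows a 1.6-fold lower number from compound 2 to compound 4 (0.20 log units; within the scatter), so this swap stays as small as the earlier one involving 4-chlorophenyl. Among these compounds, it also gives the first direct comparison of two halogens, fluoro in place of chloro on an aromatic carbon, with a 1.0-fold lower number from compound 1 to compound 4 (0.02 log units; within the scatter), so these two compounds cannot be told apart in this measurement. The 4-fluorophenyl, 4-chlorophenyl and 2-(methylsulfanyl)phenyl groups have so far given numbers that lie close together, and no further data speak to why.

The compounds shown leave open whether any group on this double-bonded chain carbon could move the number beyond the scatter, for example a phenyl ring carrying an amine or a carboxylic acid, or a longer chain in place of the ring. They also leave open whether 4-fluorophenyl would give a similar number on the core of compound 3, which has hydrogen in place of methyl on an oxygen on the aromatic ring.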